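Replacing the seven-membered ring amide: compound 1 to compound 4

The source may report more compounds than this note shows. Statements on the series, on what has been measured and on what is new or still open speak of the compounds shown alone.

Compound 1 `O=C1C(Cc2n[nH]c3cc(F)ccc23)C(=O)N(c2ccccc2)C=CN1CC(=O)N1CCCCc2ccccc21` gives 437 nM in a functional assay on CHO cells for agonist activity at Melanocortin receptor 4 (Homo sapiens), read by a luciferase reporter, with a stated time of 4 h (on this read-out higher numbers stand for an effect only at larger amounts of compound and lower numbers for an effect already at smaller amounts), the higher of the two plain numbers at hand. Compound 3 `COc1ccc(N(C(=O)CN2C=CN(c3ccccc3)C(=O)C(Cc3n[nH]c4ccccc34)(OC)C2=O)C(C)C)cc1` gives 166 nM in this assay, a gap from compound 1 that lies beyond the usual scatter. Compound 2 `CC(C)N(C(=O)CN1C=CN(c2ccccc2)C(=O)[C@@H](Cc2n[nH]c3cc(F)ccc23)C1=O)c1ccccc1` gives 31600 nM; > 30000 nM (2 entries) in this assay. Compound 4 `CC(C)N(C(=O)CN1C=CN(c2ccccc2)C(=O)C(Cc2n[nH]c3cc(F)ccc23)C1=O)c1ccc(F)cc1` differs from compound 1 by a group of 11 heavy atoms (9 carbon, 1 nitrogen, 1 fluorine; one six-membered aromatic ring of carbon only) in place of a group of 11 heavy atoms (10 carbon, 1 nitrogen; one six-membered aromatic ring of carbon only, one seven-membered non-aromatic ring with 1 hetero atom), on a carbonyl carbon. Going by the values given here, no measured pair shows this change directly, but compound 2, whose amide is closest in make-up to that of compound 4, lies far from compound 1, while compound 3 stays well within the active range. The step from compound 1 to compound 4 is therefore expected to raise the number, a 5.7-fold higher number from compound 1 to compound 4 (0.76 log units; beyond the scatter). Compound 4 is estimated at 2500 nM, within a range of 300 nM to 20000 nM.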

Compound 4, half-maximal effective concentration: 178 nM
Estimate against measurement, compound 4: 14-fold (1.15 log units) above, outside the stated range (below it).
By their numbers in this assay, from the lowest: compounds 3 and 4 (each within the scatter of the next); then compound 1.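

On the carbonyl carbon, the seven-membered non-aromatic ring is not required for activity in this assay: the group without it gives a 2.5-fold lower number from compound 1 to compound 4 (0.39 log units; beyond the scatter), a modest step. This could not be read from compound 2, which alone had carried a comparable group and whose record holds a plain number beside limits of the assay: the several entries of compound 2 in this assay, 31600 nM; > 30000 nM (2 entries)

The compounds shown do not settle what separates compound 4 from compound 2. From the compounds shown here alone, how an amine or a carboxylic acid on the six-membered aromatic ring would read in this assay also stays open.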